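Series notes: aryl ether versus benzyl at the quinoline position

The source may report more compounds than this note shows. Statements on the series, on what has been measured and on what is new or still open speak of the compounds shown alone.

Measured compounds:
compound 1, `COc1cccc(CNCCCNc2ccnc3cc(Oc4ccc(F)cc4)ccc23)c1O`, 11000 nM
compound 2, `COc1cccc(CNCCCNc2ccnc3cc(Cc4ccc(F)cc4)ccc23)c1O`, 4780 nM
compound 3, `COc1cccc(CNCCCNc2ccnc3cc(Cc4ccc(F)cc4Cl)ccc23)c1O`, 2350 nM

In an ADME assay on HepG2 cells (Homo sapiens) for cytotoxicity, read by luminescence, CellTiter-Glo and ATP content, with a stated time of 72 h (on this read-out lower numbers stand for an effect already at smaller amounts and higher numbers for an effect only at larger amounts of compound), compound 3 gives the lowest of the three numbers; compound 2 sits nearest with a 2.0-fold lower number from compound 2 to compound 3 (0.31 log units; beyond the scatter), compound 1 furthest with a 4.7-fold lower number from compound 1 to compound 3 (0.67 log units; beyond the scatter). Compound 4, `COc1ccccc1Oc1ccc2c(NCCCNCc3cccc(OC)c3O)ccnc2c1`, is the next candidate for this assay. Its change against compound 3 is 2-methoxyphenoxy in place of 2-chloro-4-fluorobenzyl on an aromatic carbon.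

For the measured compounds named here, two measured steps bear on this. The exchange of 4-fluorophenoxy for a benzyl group lowered the number, a 2.3-fold lower number from compound 1 to compound 2 (0.36 log units; beyond the scatter), and the added chloro lowered it again, a 2.0-fold lower number from compound 2 to compound 3 (0.31 log units; beyond the scatter); both together gave a 4.7-fold lower number from compound 1 to compound 3 (0.67 log units; beyond the scatter). From the compounds shown here alone, compound 4 reverses both at once: the linking oxygen returns and the chloro leaves, while the 2-methoxyphenoxy is a new group with no measured comparator here, so its own contribution is unknown. The expectation is therefore a rise back towards the number of compound 1, beyond the scatter, estimated as a 3.8-fold higher number from compound 3 to compound 4 (0.58 log units; beyond the scatter).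

Compound 4 is expected to give about 9000 nM, within a range from 3500 nM to 25000 nM.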

Compound 4, half-maximal effective concentration: 11200 nM
Compound 4: the middle estimate sits 1.2-fold (0.09 log units) below what was measured; measured number inside the range.
By their numbers in this assay, from the lowest: compound 3; then compound 2; then compounds 1 and 4 (each within the scatter of the next).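

In this assay, the phenoxy position now has a second aryl ether: 2-methoxyphenyl in place of 4-fluorophenyl on the oxygen leaves the two ethers unseparated (a 1.0-fold higher number from compound 1 to compound 4 (0.01 log units; within the scatter)), so this exchange on the aryl ring does not register in the read-out. The benzyl compounds also stand lower than this second ether (a 2.3-fold higher number from compound 2 to compound 4 (0.37 log units; beyond the scatter); a 4.8-fold higher number from compound 3 to compound 4 (0.68 log units; beyond the scatter)), which means that the gap seen earlier between benzyl and phenoxy groups is no longer tied to 4-fluorophenoxy alone, although the largest step also carries a change of ring substituents. No supporting measurement is available to explain the difference between these benzyl and phenoxy groups.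

Still open, from the compounds shown here alone, is how far the linking atom and the ring substituents each count, which matched 2-methoxybenzyl and 2-chloro-4-fluorophenoxy groups would help to separate. The compounds shown also leave open how a 4-fluoroanilino group, with nitrogen as the link, or a morpholine at this position would read in this assay.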